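The source may report more compounds than this note shows. Statements on the series, on what has been measured and on what is new or still open speak of the compounds shown alone.

Compound 1 `CC(C)C[C@H](N)CN(C(=O)[C@@H]1C[C@H]1c1ccccc1)c1ccc(-c2ccncc2)cc1` and compound 2 `CC(C)C[C@H](N)CN(C(=O)[C@@H]1C[C@H]1c1ccccc1)c1ccc(-c2ccsc2)cc1` share a core and differ only in the ring that hangs from one aromatic carbon. In a functional assay for agonist activity at G protein-coupled receptor 88 (Homo sapiens), read by HTRF and cAMP accumulation (on this read-out higher numbers stand for an effect only at larger amounts of compound and lower numbers for an effect already at smaller amounts), compound 1 gives 13000 nM. In this assay compound 2 gives 1200 nM, so the exchange from compound 1 to compound 2 brings an 11-fold lower number from compound 1 to compound 2 (1.03 log units; beyond the scatter). Compound 2 therefore holds the lowest of the two numbers seen, with compound 1 standing well apart from it.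

Compound 3 `CC(C)C[C@H](N)CN(C(=O)[C@@H]1C[C@H]1c1ccccc1)c1ccc(-c2cccs2)cc1` is the next variation. Its difference from compound 2 is thiophen-2-yl in place of thiophen-3-yl on an aromatic carbon. This is a change of attachment point within an otherwise identical ring, which is a smaller move than the swap behind the step from compound 1 to compound 2. Among the measured compounds shown here, that single measured step is the only one available, and it concerns a different kind of exchange, so it offers limited guidance here; the data hold no step in which one thiophenyl isomer replaces the other. The expectation for compound 3 in this assay is therefore a step of about a 1.3-fold higher number from compound 2 to compound 3 (0.10 log units; within the scatter), not beyond the scatter. Compound 3 is thus estimated at 1500 nM, with a range from 500 nM to 5000 nM.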

Compound 3, half-maximal effective concentration: 1500 nM
Beside the measured number, compound 3's estimate shows no gap at the digits printed; low and high end bracket the measured number.
By their numbers in this assay, from the lowest: compounds 2 and 3 (each within the scatter of the next); then compound 1.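

Compound 2 showed that one thiophene ring could sit on this aromatic carbon with a far lower number than the pyridin-4-yl ring of compound 1, but it could not show whether that result depended on the ring's attachment point. In this assay, thiophen-2-yl and thiophen-3-yl cannot be told apart at this position, which is para to a large group (a 1.3-fold higher number from compound 2 to compound 3 (0.10 log units; within the scatter)), so the way the sulfur-containing ring is joined has no readable effect here. The difference from pyridin-4-yl therefore holds for both thiophene attachments, and the comparison with compound 1 stands clear of the scatter for compound 3 (an 8.7-fold lower number from compound 1 to compound 3 (0.94 log units; beyond the scatter)) as it does for compound 2 (an 11-fold lower number from compound 1 to compound 2 (1.03 log units; beyond the scatter)), while nothing available here explains this difference.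

As far as these compounds go, with only these three rings in hand, it remains open whether a phenyl or furanyl ring on the same carbon would give a number near those of compound 2 and compound 3 or one near that of compound 1. From the compounds shown here alone, it is also open whether a methyl group or a chlorine atom on the thiophene ring would leave the number in this assay where it stands.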